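Swapping a Fluorophenyl for Cyclopentyl on a Second Core

The compounds below may be only part of what the source reports. "The series", "measured", "known", "first", "only" and "open" are said of these compounds alone.

Compound 1 `O=C1Nc2c(ccc(F)c2F)C1(c1ccc(O)cc1)c1ccc(F)cc1` and compound 2 `O=C1Nc2c(ccc(F)c2F)C1(c1ccc(O)cc1)C1CCCC1` share one core. In a functional assay on MCF7 cells (Homo sapiens) for cytotoxicity, read by WST assay, with a stated time of 72 h (a lower number here means a stronger inhibitor, a higher number a weaker inhibitor), compound 1 gives 2.6 nM, and compound 2 gives 12 nM. The change between them is cyclopentyl in place of 4-fluorophenyl on a saturated ring carbon and the step it made is a 4.6-fold higher number from compound 1 to compound 2 (0.66 log units; beyond the scatter). Compound 3 `COc1ccc2c(c1C)NC(=O)C2(c1ccc(O)cc1)c1ccc(F)cc1` sits on a different core; the difference between the two cores is not broken down here. In this assay compound 3 gives 6.3 nM. Compound 4 `COc1ccc2c(c1C)NC(=O)C2(c1ccc(O)cc1)C1CCCC1` differs from compound 3 by cyclopentyl in place of 4-fluorophenyl on a saturated ring carbon, the same change made at the same place. Because the earlier step was a 4.6-fold higher number from compound 1 to compound 2 (0.66 log units; beyond the scatter), the step expected here is estimated as a 4.6-fold higher number from compound 3 to compound 4 (0.66 log units; beyond the scatter). On that basis compound 4 is expected to give about 29 nM in this assay, most likely between 12 nM and 70 nM.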

Compound 4, half-maximal inhibitory concentration: 1 nM
Beside the measured number, compound 4's estimate is 29-fold (1.46 log units) above it, outside the stated range (below it).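

In this assay, putting cyclopentyl in place of 4-fluorophenyl gave a 6.3-fold lower number from compound 3 to compound 4 (0.80 log units; beyond the scatter), so the effect seen on the first core did not carry over to the second. The two steps run in opposite directions, and the gap between them is real: the same change on two cores in this assay, a 4.6-fold higher number (0.66 log units; beyond the scatter) from compound 1 to compound 2 and a 6.3-fold lower number (0.80 log units; beyond the scatter) from compound 3 to compound 4, 29-fold (1.46 log units) apart, beyond the scatter of two such steps This shows that what the swap does depends on the core carrying it, but it does not show which feature of the cores is responsible, and two pairs set no rule for any further core.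

The compounds shown leave open how a cyclohexyl ring, a longer chain or an amine would behave on a saturated ring carbon of either core. They also leave open which single difference between the two cores reverses the step.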